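The compounds below may be only part of what the source reports. "The series", "measured", "known", "first", "only" and "open" are said of these compounds alone.

Measured in a functional assay on MDA-MB-436 cells (Homo sapiens) for antiproliferative activity, read by MTT assay, with a stated time of 48 h; a higher number here means a weaker inhibitor, a lower number a stronger inhibitor:
- compound 1 `CN1CCN(c2ccc(-c3cc4c(N5CCN(S(=O)(=O)/C=C/c6ccccc6)CC5)ncnc4s3)cc2)CC1`: 8670 nM
- compound 2 `CN1CCN(c2ccc(-c3cc4c(N5CCN(S(=O)(=O)C6CC6)CC5)ncnc4s3)cc2)CC1`: 10600 nM
- compound 3 `COc1ccc(NC(=O)N2CCN(c3ncnc4sc(-c5ccc(N6CCN(C)CC6)cc5)cc34)CC2)cc1`: 30100 nM

Compound 3 gives the highest number of the three and is the weakest here. Compound 4 `CN1CCN(c2ccc(-c3cc4c(N5CCN(C(=O)Nc6ccc(C#N)cc6)CC5)ncnc4s3)cc2)CC1` differs from it by cyano in place of methoxy on an aromatic carbon, para to a large group.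

Among the compounds with values here, no measured step touches this substituent. The nearest evidence is exchange of the whole group on the ring amine nitrogen: a 3.5-fold higher number from compound 1 to compound 3 (0.54 log units; beyond the scatter) and a 2.8-fold higher number from compound 2 to compound 3 (0.45 log units; beyond the scatter), both modest, while a 1.2-fold higher number from compound 1 to compound 2 (0.09 log units; within the scatter). A smaller exchange should move less, so no step beyond the scatter is expected in this assay.

The expected step is a 1.2-fold lower number from compound 3 to compound 4 (0.08 log units; within the scatter). For compound 4 the estimate is 25000 nM, with an expected range of 10000 nM to 55000 nM.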

Compound 4, half-maximal inhibitory concentration: 5010 nM
The estimate for compound 4 lay 5.0-fold (0.70 log units) above the measured number, outside the stated range (below it).
By their numbers in this assay, from the lowest: compounds 4, 1 and 2 (each within the scatter of the next, the first and the last beyond it); then compound 3.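

In this assay, within the data shown here, exchanging methoxy for cyano on this aromatic carbon gives a 6.0-fold lower number from compound 3 to compound 4 (0.78 log units; beyond the scatter), so this one substituent moves the number, whereas the earlier steps exchanged the whole group on the ring amine nitrogen. With cyano in place, the carbamoyl series no longer trails the sulfonyl compounds: there is a 2.1-fold lower number from compound 2 to compound 4 (0.33 log units; beyond the scatter), while a 1.7-fold lower number from compound 1 to compound 4 (0.24 log units; within the scatter) stays within the scatter. No measurement at hand accounts for the effect of this change.

Still open, on these data alone, is how an amine, a carboxylic acid or a chlorine on this carbon would compare with cyano and methoxy. Also open, as far as these compounds go, is whether the cyano gain persists with a longer chain between the carbamoyl nitrogen and the aromatic ring.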